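The source may report more compounds than this note shows. Statements on the series, on what has been measured and on what is new or still open speak of the compounds shown alone.

Measured so far:
Compound 1 `Oc1ccccc1-c1cc(-c2ccccc2F)cc(-c2ccccc2O)n1` gives > 50000 nM in a functional assay on T47D cells (Homo sapiens) for inhibition; a higher number here means a weaker inhibitor, a lower number a stronger inhibitor; this is a limit of the assay, not a number.
Compound 2 `Oc1cccc(-c2cc(-c3ccccc3F)cc(-c3ccccc3O)n2)c1` gives 24200 nM in this assay.

Compound 1 sits at the limit of > 50000 nM in this assay, at which 1 of the 2 values shown sits. Within the data shown here, compound 2 therefore holds the only number so far in this assay; there is no second number against which it could be ranked.

Compound 3 `Oc1cccc(-c2cc(-c3ccc(F)cc3)cc(-c3ccccc3O)n2)c1` has not yet been measured. It differs from compound 2 by 4-fluorophenyl in place of 2-fluorophenyl on an aromatic carbon, the exchanged group standing on an aromatic carbon of a six-membered aromatic ring with 1 nitrogen, opposite the ring nitrogen.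

Among the measured compounds shown here, only one measured step exists, an at least 2.0-fold lower number from compound 1 to compound 2 (0.31 log units; beyond the scatter), and it concerns the hydroxyphenyl group, not the fluorophenyl group. For the measured compounds named here, no measured step touches the change from compound 2 to compound 3, so there is no direct guide to its size or direction. In the absence of such evidence, a step within the scatter is expected, namely a 1.1-fold lower number from compound 2 to compound 3 (0.04 log units; within the scatter). Compound 3 is accordingly estimated at 22000 nM in this assay, with a range from 8000 nM to 60000 nM, and a real chance that the assay again reports only a limit.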

Compound 3, half-maximal inhibitory concentration: > 50000 nM
Compound 3 was reported as a limit; the forecaster's own chance of this, stated with the estimate: 30%; at least 2.2-fold (0.35 log units) between middle value and limit.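

In this assay compound 3 gives > 50000 nM, which is a limit of the assay and not a number. The earlier step concerned only the hydroxyphenyl group, whereas this one shows that the place opposite the ring nitrogen also responds: 4-fluorophenyl in place of 2-fluorophenyl, with the same atoms in both groups, gives an at least 2.0-fold higher number from compound 2 to compound 3 (0.31 log units; beyond the scatter), which lies beyond the scatter, so where the fluorine stands on this phenyl group matters in this assay, even though the group's atom content is unchanged. Compound 2 therefore remains the only compound here with a number, and the other two compounds give no measure of how far they lie from it: the limit of > 50000 nM in this assay, at which 2 of the 3 values shown sit.

From the compounds shown here alone, the true size of the step remains open, as the limit fixes only its smallest possible value, and so does the question of whether fluorine contributes at all at this place. Going by these compounds, it is also open whether 3-fluorophenyl, an unsubstituted phenyl, or a phenyl carrying an amine or a carboxylic acid at this place would give a lower number than compound 2 does.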